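The source may report more compounds than this note shows. Statements on the series, on what has been measured and on what is new or still open speak of the compounds shown alone.

Compound 1 `Cn1cc(C2CC(c3ccccc3)=NN2C(=O)c2cccnc2)c2ccccc21` in a functional assay on HeLa cells (Homo sapiens) for inhibition, read by MTT assay, with a stated time of 48 h (on this read-out lower numbers stand for stronger inhibition of growth and higher numbers for weaker inhibition of growth), gives only a limit, > 10000 nM. Compound 2 `Cc1ccc(C(=O)N2N=C(c3ccccc3)CC2c2cn(C)c3ccccc23)cn1` in this assay gives 2390 nM. Compound 3 `COc1cccc(C2=NN(C(=O)c3cccnc3)C(c3cn(C)c4ccc(OC)cc34)C2)c1` in this assay gives 1270 nM.

The change from compound 1 to compound 2, (methyl in place of hydrogen on an aromatic carbon), produced an at least 4.1-fold lower number from compound 1 to compound 2 (0.62 log units; beyond the scatter); its true size is uncertain, since (the limit of > 10000 nM in this assay, at which 1 of the 3 values shown sits). The values of compound 2 and compound 3 lie within the scatter of each other, and the difference between their cores is not broken down here.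

Compound 4 `COc1cccc(C2=NN(C(=O)c3ccc(C)nc3)C(c3cn(C)c4ccc(OC)cc34)C2)c1` carries the same change on the core of compound 3, (methyl in place of hydrogen on an aromatic carbon). Given an at least 4.1-fold lower number from compound 1 to compound 2 (0.62 log units; beyond the scatter), a lowering of the number is expected for compound 4 in this assay, of about a 2.5-fold lower number from compound 3 to compound 4 (0.40 log units; beyond the scatter). Compound 4 is therefore estimated at 500 nM, within 150 nM to 1500 nM.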

Compound 4, concentration for 50% growth inhibition: 34 nM
Compound 4: middle estimate off by 15-fold (1.17 log units), on the high side; the measured number lies below the stated range.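

Going from pyridin-3-yl to 6-methylpyridin-3-yl on the core of compound 3 gave, in this assay, a 37-fold lower number from compound 3 to compound 4 (1.57 log units; beyond the scatter), so the lowering of the number seen on the core of compound 1 appeared on this second core as well. Whether its size carried over cannot be told, since compound 1 gives only a limit: the same change on two cores in this assay, an at least 4.1-fold lower number (0.62 log units; beyond the scatter) from compound 1 to compound 2 and a 37-fold lower number (1.57 log units; beyond the scatter) from compound 3 to compound 4; the limit leaves it open whether they differ. Two cores are all that is shown, so this says nothing about how the change would read on any other core in the series.

The compounds shown leave open how ethyl, methoxy or an amine would read in place of the methyl at this position. Among the compounds shown here, they also leave open whether a core with only one methoxy group would respond in the same way.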